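The compounds below may be only part of what the source reports. "The series", "measured", "known", "first", "only" and "open" are said of these compounds alone.

Values in an ADME assay on HEK-293T cells (Homo sapiens) for cytotoxicity, read by MTT assay, with a stated time of 48 h; a lower number here means that less compound is tolerated, a higher number that more compound is tolerated:
Compound 1 `COc1ccc(C(=O)N2N=C(c3ccccc3)CC2c2cn(C)c3ccccc23)cn1`: > 300000 nM (a limit of the assay)
Compound 2 `Cc1ccc(C(=O)N2N=C(c3ccccc3)CC2c2cn(C)c3ccccc23)cn1`: 154000 nM
Compound 3 `Cn1cc(C2CC(c3ccccc3)=NN2C(=O)c2ccncc2)c2ccccc21`: 97300 nM

Compound 2 and compound 3 lie within the scatter of each other, as a 1.6-fold lower number from compound 2 to compound 3 (0.20 log units; within the scatter) shows. Compound 1 is known only as a limit, > 300000 nM.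

The step followed here leads to compound 4 `COc1cc(C2=NN(C(=O)c3ccc(C)nc3)C(c3cn(C)c4ccccc34)C2)cc(OC)c1OC`, which keeps the (6-methylpyridin-3-yl)carbonyl group of compound 2 but carries 3,4,5-trimethoxyphenyl in place of phenyl on a carbon with a double bond to nitrogen. For the measured compounds named here, no measured step changes this phenyl, so the evidence is indirect. The closest parallel is an at least 1.9-fold lower number from compound 1 to compound 2 (0.28 log units; that floor lies within the scatter), which swaps methoxy for methyl on an aromatic carbon elsewhere in the molecule and has a floor within the scatter. Changes to the group on the carbonyl carbon give a 1.6-fold lower number from compound 2 to compound 3 (0.20 log units; within the scatter) and an at least 3.0-fold lower number from compound 1 to compound 3 (0.48 log units; beyond the scatter), and only the latter goes beyond the scatter. These steps are small, and none shows what the added methoxy groups do at the new place. No step beyond the scatter is therefore expected in this assay, and the data favour no clear direction. The expected change is a 1.2-fold lower number from compound 2 to compound 4 (0.09 log units; within the scatter). Compound 4 is estimated at 125000 nM, with an expected range of 40000 nM to 280000 nM.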

Compound 4, half-maximal cytotoxic concentration: > 300000 nM
Compound 4: no number, only a limit; the forecaster's own chance of this, stated with the estimate: 20%; at least 2.4-fold (0.38 log units) between middle value and limit.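

In this assay, for the compounds shown here, putting 3,4,5-trimethoxyphenyl in place of phenyl gives an at least 1.9-fold higher number from compound 2 to compound 4 (0.28 log units; that floor lies within the scatter), so the first reading at this carbon with a double bond to nitrogen shows no fall in the number when the methoxy groups enter. Compound 4 gives > 300000 nM, which is a limit of the assay and not a number. Whether the step truly goes beyond the scatter cannot be told, because the reading for compound 4 stops at the top of what the assay reports: the limit of > 300000 nM in this assay, at which 2 of the 4 values shown sit.

The compounds shown leave open whether a phenyl with a single methoxy group, a chlorine on the phenyl, or an amine on the phenyl would read the same way at this place in this assay, and so which part of the 3,4,5-trimethoxyphenyl group goes with this result. From the compounds shown here alone, it also stays open whether the same change holds when the group on the carbonyl carbon is the pyridin-4-yl of compound 3 rather than the (6-methylpyridin-3-yl)carbonyl group of compound 2.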